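A few compounds are considered here, and "the series" means these few. Any claim that something is new, unique, unknown or untested is made for them only; others in the source may bear on it.

The three measured compounds share one core. Compound 1 `Cc1c2c(n3c1CCCNC[C@H](C)Nc1cc-3ccc1C(N)=O)CC(C)(C)CC2=O` carries a free ring amine, and in a physicochemical assay for solubility, at pH 7.4 (on this read-out lower numbers stand for lower solubility and higher numbers for higher solubility), compound 1 returns only the limit of the method, > 100 ug/mL, not a number. Compound 2 `CC(=O)N1CCc2c(C)c3c(n2-c2ccc(C(N)=O)c(c2)N[C@@H](C)[C@H](C)C1)CC(C)(C)CC3=O` bears an acetyl on that ring nitrogen, and in this assay compound 2 gives 38 ug/mL. Compound 3 `CC[C@H](N)C(=O)N1CCc2c(C)c3c(n2-c2ccc(C(N)=O)c(c2)N[C@@H](C)[C@H](C)C1)CC(C)(C)CC3=O` differs from compound 2 by 1-aminopropyl in place of methyl on a carbonyl carbon. In this assay compound 3 again reaches only the limit, > 100 ug/mL. For the measured compounds named here, the single measured step, an at least 2.6-fold higher number from compound 2 to compound 3 (0.42 log units; beyond the scatter), is beyond the scatter, and its full size is unknown because of the limit of > 100 ug/mL in this assay, at which 2 of the 3 values shown sit. Compound 3 therefore stands at the upper edge of what this assay can report.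

Compound 4 `Cc1c2c(n3c1CCN(C(=O)C1(N)CC1)C[C@@H](C)[C@H](C)Nc1cc-3ccc1C(N)=O)CC(C)(C)CC2=O` differs from compound 3 by 1-aminocyclopropyl in place of 1-aminopropyl on a carbonyl carbon. Going by the values given here, no measured step covers this exact exchange; the one step that bears on it, from compound 2 to compound 3, shows that the carbonyl carbon tolerates an amino-bearing group while solubility rises at least modestly, and compound 4 keeps such a group. Compound 4 is therefore expected to remain near the limit, with a step of a number no higher from compound 3 to compound 4 (the limit leaves the size open) that is not expected to exceed the scatter. The estimate for compound 4 in this assay is 100 ug/mL, between 50 ug/mL and 200 ug/mL.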

Compound 4, solubility: 7 ug/mL
Compound 4: middle estimate off by 14-fold (1.15 log units), on the high side, outside the stated range (below it).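

At this carbonyl carbon, an amino-bearing group does not by itself keep the read-out high: in this assay, 1-aminocyclopropyl in place of 1-aminopropyl gives an at least 14-fold lower number from compound 3 to compound 4 (1.15 log units; beyond the scatter), although the two groups differ in the computed comparison only by the three-membered ring and the defined stereocentre. The rise seen with 1-aminopropyl therefore does not carry over to every amino-bearing group, since the methyl-bearing acetyl of compound 2 compares favourably with the new group, with a 5.4-fold lower number from compound 2 to compound 4 (0.73 log units; beyond the scatter). The step from compound 3 remains a bound and its full size stays unknown because compound 3 sits at a limit: the limit of > 100 ug/mL in this assay, at which 2 of the 4 values shown sit.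

The compounds shown leave open whether the fall follows from the closed three-membered ring or from the loss of the stereocentre, a question on which an open 1-amino-1-methylethyl group or a larger 1-aminocyclobutyl ring on the same carbonyl carbon would bear. They also leave open how much the amine itself contributes, which a cyclopropyl group without the amine at this place would address.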